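The source may hold more compounds than are shown below. What is called first, only, known or untested is meant among the compounds shown, and "the series" means these compounds.

Working notes on the series

Compound 1 `O=c1ccoc(/C=C/c2ccccc2)c1` is the parent. In a functional assay on 786-0 cells (Homo sapiens) for inhibition, read by sulforhodamine B assay, with a stated time of 48 h (on this read-out lower numbers stand for stronger inhibition of growth and higher numbers for weaker inhibition of growth), compound 1 gives 410 uM. Compound 2 `COc1ccc(/C=C/c2cc(=O)cco2)cc1` carries the change (methoxy in place of hydrogen on an aromatic carbon), and in this assay compound 2 gives 377 uM; the step is a 1.1-fold lower number from compound 1 to compound 2 (0.04 log units; within the scatter).

Compound 3 `COc1ccc(/C=C/C2CC=CC(=O)N2)cc1OC` is built on a different core, and the difference between the two cores is not broken down here. In this assay compound 3 gives only a limit of the assay, not a number, > 964 uM, which is the limit of > 964 uM in this assay, at which 1 of the 3 values shown sits.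

Compound 4 `COc1cc(OC)c(OC)cc1/C=C/C1CC=CC(=O)N1` is not yet measured. It differs from compound 3 by methoxy in place of hydrogen on an aromatic carbon, the same kind of change as that from compound 1 to compound 2, though the surroundings differ: in compound 2 the methoxy sits para to a group of 9 heavy atoms, whereas in compound 4 it sits ortho to a group of 9 heavy atoms, meta to a methoxy group and para to a methoxy group. The expected step in this assay is a step that the limit leaves unreadable from compound 3 to compound 4, because the same change once gave a 1.1-fold lower number from compound 1 to compound 2 (0.04 log units; within the scatter). Since compound 3 already sits at the limit, compound 4 is expected to remain there too. For compound 4 the estimate in this assay is 1000 uM, with a range of 400 uM to 3000 uM.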

Compound 4, concentration for growth inhibition (reported as GI): > 864 uM
Compound 4 was reported as a limit; the forecaster's own chance of this, stated with the estimate: 75%; the middle value lies beyond the limit too.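

Compound 3 gives > 964 uM in this assay, which is a limit, not a number. For the compounds shown here, compound 4 gives > 864 uM, also a limit, so no step between compound 3 and compound 4 can be read. The compounds shown leave open whether methoxy in place of hydrogen changes growth inhibition on the core of compound 3.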